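Adding a Methoxy Group to Compound 2

The source may hold more compounds than are shown below. What is called first, only, known or untested is meant among the compounds shown, and "the series" means these compounds.

Of the compounds shown here, two sharing one core have been tested in a functional assay on HOP-92 cells (Homo sapiens) for inhibition; on this read-out higher numbers stand for weaker inhibition of growth and lower numbers for stronger inhibition of growth. Compound 1 `O=C(/C=C/c1cccc(O)c1)c1cccc(-n2cc(-c3ccccc3)[nH]c2=O)c1` gives 5040 nM. Compound 2 `COc1cc(/C=C/C(=O)c2cccc(-n3cc(-c4ccccc4)[nH]c3=O)c2)cc(OC)c1OC` gives 10800 nM, the higher of the two numbers, and its gap to compound 1 lies beyond the usual scatter, so compound 2 is the weaker growth inhibitor of the pair. Compound 3 `COc1ccc(-c2cn(-c3cccc(C(=O)/C=C/c4cc(OC)c(OC)c(OC)c4)c3)c(=O)[nH]2)cc1` has not yet been measured. It differs from compound 2 in one place: methoxy in place of hydrogen on an aromatic carbon, placed para to a large group, so that a phenyl becomes a 4-methoxyphenyl. Among the measured compounds shown here, no measured pair shows what this particular change does, so no direction can be read from the numbers. On that basis the expected step is a 1.1-fold lower number from compound 2 to compound 3 (0.06 log units; within the scatter), that is, none beyond the usual scatter. Compound 3 is therefore estimated at 9500 nM in this assay, with a likely range from 3500 nM to 26000 nM.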

Compound 3, concentration for 50% growth inhibition: 14900 nM
Compound 3: the middle estimate sits 1.6-fold (0.20 log units) below what was measured; low and high end bracket the measured number.
By their numbers in this assay, from the lowest: compound 1; then compounds 2 and 3 (each within the scatter of the next).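

In this assay, among the compounds shown here, the change from phenyl to 4-methoxyphenyl gives a 1.4-fold higher number from compound 2 to compound 3 (0.14 log units; within the scatter) and so gives the first direct reading of what methoxy does at this position. Compounds 2 and 3 cannot be told apart on this read-out, which means that this position accepts the added methoxy with no shift beyond the usual scatter of repeated measurements. No supporting data are available to explain this result.

For the compounds shown here, this single pair covers only one group at one position on one version of the shared core. As far as these compounds go, how an amine or a carboxylic acid in the same place would read remains open, as does whether methoxy would behave the same way in a compound whose other ring carries different groups.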